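Tolerability notes on compound 3 and its benzyl analogue

A few compounds are considered here, and "the series" means these few. Any claim that something is new, unique, unknown or untested is made for them only; others in the source may bear on it.

Going by the values given here, in an ADME assay on RAW264.7 cells (Mus musculus) for cytotoxicity, read by resazurin assay, with a stated time of 48 h (a lower number here means that less compound is tolerated, a higher number that more compound is tolerated), compound 3 `CC1=CC(=O)/C(=C(/C)Nc2ccc3c(Cl)n(C)nc3c2)C(=O)O1` gives 6260 nM, the only number in the set. Compound 1 `CC1=CC(=O)/C(=C(/C)Nc2ccc3cnn(C)c3c2)C(=O)O1` reaches a limit of the assay at > 100000 nM. Compound 2 `C=CCn1nc(Cl)c2ccc(N/C(C)=C3\C(=O)C=C(C)OC3=O)cc21` likewise reaches a limit at > 100000 nM. Among the compounds with values here, compound 3 therefore stands alone as the one compound falling short of the limit of > 100000 nM in this assay, at which 2 of the 3 values shown sit. Compound 4 `CC1=CC(=O)/C(=C(/C)Nc2ccc3c(Cl)n(Cc4ccc(C)cc4)nc3c2)C(=O)O1` carries 4-methylphenyl in place of hydrogen on a saturated chain carbon bound to an aromatic nitrogen. Within the data shown here, no measured pair shows this kind of change; compound 2 and compound 3 differ in the group on the aromatic nitrogen, and there a limit stands against a number. The step from compound 3 to compound 4 is expected to be modest, a 1.9-fold higher number from compound 3 to compound 4 (0.28 log units; within the scatter), with the direction open. Compound 4 is estimated at 12000 nM, within 3000 nM to 60000 nM.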

Compound 4, half-maximal cytotoxic concentration: > 100000 nM
Compound 4 gave a limit, no number (the forecaster's own chance of this, stated with the estimate: 25%); at least 8.3-fold (0.92 log units) between middle value and limit.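

Methyl to 4-methylbenzyl on the aromatic nitrogen gives an at least 15-fold higher number from compound 3 to compound 4 (1.20 log units; beyond the scatter), the first step at this position that can be read, and it lies on the more tolerated side. Going by these compounds, compound 4 gives > 100000 nM, a limit and not a number, so the step is a bound and its full size stays unknown. Compound 3 is now the only compound short of that limit: the limit of > 100000 nM in this assay, at which 3 of the 4 values shown sit.

No order can be read among compound 1, compound 2 and compound 4, since all three are limits. On these data alone, how an amine or a carboxylic acid in place of the 4-methylphenyl would read in this assay stays open.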